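The compounds below may be only part of what the source reports. "The series", "measured", "known", "first", "only" and "open" are said of these compounds alone.

In a functional assay on MGC-803 cells (Homo sapiens) for inhibition, read by MTT assay, with a stated time of 48 h (a higher number here means a weaker inhibitor, a lower number a stronger inhibitor), three compounds sharing one core have been measured. Compound 1 `COc1ccc(CN(C(C)=O)c2cc(OC)c(OC)c(OC)c2)cc1O` gives 79 nM, compound 2 `CC/C=C/C(=O)N(Cc1ccc(OC)c(O)c1)c1cc(OC)c(OC)c(OC)c1` gives 58 nM, and compound 3 `COc1ccc(CN(C(=O)CN=[N+]=[N-])c2cc(OC)c(OC)c(OC)c2)cc1O` gives 120 nM. Two steps show where the azidomethyl compound stands: a 1.5-fold higher number from compound 1 to compound 3 (0.18 log units; within the scatter), and a 2.1-fold higher number from compound 2 to compound 3 (0.32 log units; beyond the scatter).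

Compound 4 `COc1ccc(CN(C(=O)/C=C/CBr)c2cc(OC)c(OC)c(OC)c2)cc1O` has not been measured yet. It carries 3-bromoprop-1-en-1-yl in place of azidomethyl on a carbonyl carbon. Going by the values given here, no measured compound contains bromine, so no step speaks to that atom directly. The closest measured group is the but-1-en-1-yl of compound 2, which also has a double bond in its chain. Swapping methyl for that group gave a 1.4-fold lower number from compound 1 to compound 2 (0.13 log units; within the scatter), so the chain tolerated this kind of change. Read in reverse, the modest step of a 2.1-fold higher number from compound 2 to compound 3 (0.32 log units; beyond the scatter) suggests that leaving azidomethyl for an alkenyl chain could lower the number by a similar amount in this assay. The expected change is therefore a 2.0-fold lower number from compound 3 to compound 4 (0.30 log units; within the scatter), though it is only slightly beyond the scatter. For compound 4 the estimated value is 60 nM, with an expected range from 20 nM to 170 nM.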

Compound 4, half-maximal inhibitory concentration: 71 nM
The estimate for compound 4 lay 1.2-fold (0.07 log units) below the measured number; the range from low to high includes it.
By their numbers in this assay, from the lowest: compounds 2, 4, 1 and 3 (each within the scatter of the next, the first and the last beyond it).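

In this assay the position on the carbonyl carbon also accepts a chain carrying bromine, and 3-bromoprop-1-en-1-yl cannot be told apart from azidomethyl (a 1.7-fold lower number from compound 3 to compound 4 (0.23 log units; within the scatter)), from but-1-en-1-yl (a 1.2-fold higher number from compound 2 to compound 4 (0.09 log units; within the scatter)) or from methyl (a 1.1-fold lower number from compound 1 to compound 4 (0.05 log units; within the scatter)), as all three steps lie within the scatter. Going by these compounds alone, the only step here beyond the scatter remains the modest one between the but-1-en-1-yl and azidomethyl compounds (a 2.1-fold higher number from compound 2 to compound 3 (0.32 log units; beyond the scatter)), and compound 4 sits within the scatter of both, so the four groups span a narrow band. Nothing available explains why these groups read so alike.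

On these data alone, whether the double bond matters stays open, as a saturated chain carrying bromine or a chloro in place of bromo could show. Also open, as far as these compounds go, is how this position responds to an amine, a carboxylic acid or a longer chain.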